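The source may hold more compounds than are shown below. What is called first, only, known or untested is meant among the compounds shown, and "the series" means these compounds.

In a functional assay on CCRF-CEM cells (Homo sapiens), read by MTT assay, with a stated time of 3 days (a higher number here means a weaker inhibitor, a lower number a stronger inhibitor), compound 1 `CN(C)c1ncnc2[nH]cc(Sc3cccs3)c12` gives 14600 nM, compound 2 `Nc1ncnc2[nH]cc(Sc3cccs3)c12` gives 16700 nM and compound 3 `c1csc(Sc2c[nH]c3ncnc(-c4cccs4)c23)c1` gives 10600 nM. Compound 3 therefore stands level with the other two, as every gap among the three lies within the scatter. Compound 4 `c1coc(-c2ncnc3[nH]cc(Sc4cccs4)c23)c1` has furan-2-yl in place of thiophen-2-yl on an aromatic carbon. Going by the values given here, no measured step makes this exact exchange. The closest evidence comes from exchanges at the same place, which gave a 1.1-fold higher number from compound 1 to compound 2 (0.06 log units; within the scatter), a 1.4-fold lower number from compound 1 to compound 3 (0.14 log units; within the scatter) and a 1.6-fold lower number from compound 2 to compound 3 (0.20 log units; within the scatter). All three stayed within the scatter, so no step beyond the scatter is expected in this assay, in either direction. The expected result is a 1.1-fold higher number from compound 3 to compound 4 (0.05 log units; within the scatter). For compound 4 the estimated value is 12000 nM, with an expected range of 6000 nM to 24000 nM.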

Compound 4, half-maximal inhibitory concentration: 7730 nM
Estimate against measurement, compound 4: 1.6-fold (0.19 log units) above; measured number inside the range.
By their numbers in this assay, from the lowest: compounds 4, 3, 1 and 2 (each within the scatter of the next, the first and the last beyond it).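

Placed on this aromatic carbon in this assay, furan-2-yl produces the first step beyond the scatter, though a modest one: a 2.2-fold lower number from compound 2 to compound 4 (0.33 log units; beyond the scatter). By contrast, a 1.4-fold lower number from compound 3 to compound 4 (0.14 log units; within the scatter) and a 1.9-fold lower number from compound 1 to compound 4 (0.28 log units; within the scatter) both stay within the scatter, so exchanging thiophen-2-yl for furan-2-yl makes no clear difference here, and only compound 2 stands apart from compound 4. No measured evidence here explains that one separation. From the compounds shown here alone, it remains open whether a phenyl ring, a carboxylic acid or a longer chain on this same carbon would move the number further than furan-2-yl did.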